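Enlarging the amide of compound 1

The source may hold more compounds than are shown below. What is called first, only, known or untested is meant among the compounds shown, and "the series" means these compounds.

Measured so far in a functional assay on PC-3 cells (Homo sapiens) for cytotoxicity, read by XTT assay, with a stated time of 72 h; on this read-out lower numbers stand for stronger inhibition and higher numbers for weaker inhibition:
- Compound 1 `COc1ccc(OC)c(-c2cc(-c3ccc(C(=O)N(C)C)s3)on2)c1`: > 30000 nM (a limit)
- Compound 2 `CCCN(C)C(=O)c1ccc(-c2cc(C3=CC(=O)C=CC3=O)no2)s1`: < 30000 nM (a limit)

Neither measured compound has an exact number. In this assay compound 1 gives > 30000 nM, which is a limit of the assay and not a number. Compound 3 `COc1ccc(CN(C)C(=O)c2ccc(-c3cc(-c4cc(OC)ccc4OC)no3)s2)cc1` has not yet been measured. It differs from compound 1 by 4-methoxyphenyl in place of hydrogen on a saturated chain carbon bound to an amide-type nitrogen, so that methyl on the amide-type nitrogen becomes 4-methoxybenzyl. Among the measured compounds shown here, no measured pair of compounds shows this change on its own, so the expectation rests on compound 1 with > 30000 nM. In this assay no step beyond the scatter is expected, though some stronger inhibition cannot be ruled out. The expected step is a number no higher from compound 1 to compound 3 (the limit leaves the size open). For compound 3 the estimate is 30000 nM, with an expected range of 10000 nM to 60000 nM.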

Compound 3, half-maximal inhibitory concentration: > 30000 nM
Compound 3 ended at the assay's limit; the forecaster's own chance of this, stated with the estimate: 65%; the middle value lies on the limit itself.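

Compound 1 and compound 3 each stand at a limit of the assay and not at a number, and no step can be read between them. The compounds shown leave open how strongly either one inhibits in this assay, and whether 4-methoxybenzyl in place of methyl changes that at all.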